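Replacing trifluoromethyl with nitro: working notes

A few compounds are considered here, and "the series" means these few. Any claim that something is new, unique, unknown or untested is made for them only; others in the source may bear on it.

In a functional assay on HUVEC cells (Homo sapiens) for inhibition, with a stated time of 4 days (on this read-out higher numbers stand for weaker inhibition and lower numbers for stronger inhibition), compound 1 (`CCc1ccc(OC)c(COc2ccc(Cl)c(C)c2)c1`) gives 40000 nM. Compound 2 (`COc1ccc(C(N)=O)cc1/C=C/c1ccc(Br)cc1`) gives 560 nM, and compound 3 (`COc1ccc(C(N)=O)cc1/C=C/c1ccc(C(F)(F)F)cc1`) gives 880 nM. Compound 3 therefore lies within the scatter of compound 2, and both numbers sit far lower than that of compound 1.

Compound 4 (`COc1ccc(C(N)=O)cc1/C=C/c1ccc([N+](=O)[O-])cc1`) keeps the shared core of compound 3 and changes one group: nitro in place of trifluoromethyl on an aromatic carbon. This is nitro in place of trifluoromethyl on an aromatic carbon, para to a large group.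

For the measured compounds named here, only one measured step bears on this place: a 1.6-fold higher number from compound 2 to compound 3 (0.20 log units; within the scatter), for trifluoromethyl in place of bromo on an aromatic carbon. Going by the values given here, no nitro compound has been measured, and a single step is thin evidence. Even so, no step beyond the scatter is expected in this assay. The expected outcome is a 1.2-fold lower number from compound 3 to compound 4 (0.07 log units; within the scatter). The estimate for compound 4 is 750 nM, with an expected range of 300 nM to 2000 nM.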

Compound 4, half-maximal inhibitory concentration: 4700 nM
For compound 4 the middle estimate is 6.3-fold (0.80 log units) below the measured one, outside the stated range (above it).
By their numbers in this assay, from the lowest: compounds 2 and 3 (each within the scatter of the next); then compound 4; then compound 1.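

In this assay, this position turns out to respond to the group it carries: nitro gives a 5.3-fold higher number from compound 3 to compound 4 (0.73 log units; beyond the scatter), and the comparison with bromo gives an 8.4-fold higher number from compound 2 to compound 4 (0.92 log units; beyond the scatter). The earlier pair, at a 1.6-fold higher number from compound 2 to compound 3 (0.20 log units; within the scatter), stayed within the scatter and gave no hint of this, so bromo and trifluoromethyl cannot be separated here, while nitro stands apart from both as the weaker inhibitor. Nothing available accounts for the higher number with nitro.

One nitro compound cannot show whether the step belongs to nitro alone or extends to other groups at this place. Going by these compounds, an amine, a carboxylic acid or a nitrile on the same aromatic carbon of the shared core would test that, and the outcome remains open.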